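Swapping an aromatic linker for a saturated chain

This account rests on a few compounds, and the source may have more. Where it says the series, first, only, none or still open, it means among the compounds named here.

Measured in a functional assay on HepG2 cells (Homo sapiens) for inhibition, read by MTT assay, with a stated time of 72 h; a lower number here means a stronger inhibitor, a higher number a weaker inhibitor:
Compound 1 `CC(C)CCN(CCCCCCC(=O)NO)c1ncc(C(=O)NCc2cccnc2)s1`: 7000 nM
Compound 2 `O=C(/C=C/c1ccc(CN(Cc2ccc(F)cc2)c2ncc(C(=O)NCCCn3ccnc3)s2)cc1)NO`: 13000 nM

These two values lie within the usual scatter of each other, so compound 2 cannot be ranked apart from compound 1. Compound 3 `O=C(CCCCCCN(Cc1ccc(F)cc1)c1ncc(C(=O)NCCCn2ccnc2)s1)NO` differs from compound 2 in one place: 5-(hydroxycarbamoyl)pentyl in place of 4-(2-(hydroxycarbamoyl)ethenyl)phenyl on a saturated chain carbon bound to a nitrogen on an aromatic ring. A 5-(hydroxycarbamoyl)pentyl stands in place of the 4-(2-(hydroxycarbamoyl)ethenyl)phenyl, on a saturated chain carbon bound to a nitrogen on an aromatic ring.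

Going by the values given here, no two measured compounds differ in only one place, so no direct step can guide the expectation. The nearest clue is compound 1, which carries the same 5-(hydroxycarbamoyl)pentyl and gives 7000 nM, although it also differs elsewhere. The estimated step of a 1.6-fold lower number from compound 2 to compound 3 (0.21 log units; within the scatter) is small, toward a lower number, and is expected to stay within the scatter. For compound 3 the expected value is 8000 nM, with an estimated range of 3000 nM to 20000 nM.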

Compound 3, half-maximal inhibitory concentration: 9400 nM
Beside the measured number, compound 3's estimate is 1.2-fold (0.07 log units) below it; the measured number falls inside the stated range.
By their numbers in this assay, from the lowest: compounds 1, 3 and 2 (each within the scatter of the next).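

In this assay, going by these compounds alone, the swap gives a 1.4-fold lower number from compound 2 to compound 3 (0.14 log units; within the scatter) on a saturated chain carbon bound to a nitrogen on an aromatic ring, the first direct reading of a change at this place. Compound 3 has no ring in this group and one double bond fewer outside aromatic rings, yet the 5-(hydroxycarbamoyl)pentyl and the 4-(2-(hydroxycarbamoyl)ethenyl)phenyl cannot be told apart in this pair. Nothing measured here accounts for how closely the two compounds read.

On these data alone, whether a longer chain, such as 7-(hydroxycarbamoyl)heptyl, or a shorter one, such as 3-(hydroxycarbamoyl)propyl, would also stay within the scatter remains open. As far as these compounds go, it is also open whether the same swap would read alike with different groups elsewhere on the core, such as those carried by compound 1.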